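Chloro in Place of Hydrogen: Expected Inhibition for Compound 4

A few compounds are considered here, and "the series" means these few. Any claim that something is new, unique, unknown or untested is made for them only; others in the source may bear on it.

Measured so far:
- compound 1 `O=C(CCc1nnc(-c2ccccc2)o1)c1ccccc1` gives 18.7% in a functional assay on the whole organism (strain Wistar) for inhibition, with Rattus norvegicus as the target, with stated times of 30 min and 2 h, at a dose of 20 mg/kg by the oral route; on this read-out lower numbers stand for less inhibition and higher numbers for more inhibition at the one dose given (going by the name of the read-out)
- compound 2 `O=C(CCc1nnc(-c2ccc(Cl)cc2)o1)c1ccccc1` gives 42% in this assay
- compound 3 `Cc1ccc(C(=O)CCc2nnc(-c3ccccc3)o2)c(C)c1` gives 36% in this assay

Compound 2 differs from compound 1 by chloro in place of hydrogen on an aromatic carbon and the step is a number 23.3 percentage points higher from compound 1 to compound 2 (beyond the scatter). The difference between the cores of compound 1 and compound 3 is not broken down here. Compound 4 `Cc1ccc(C(=O)CCc2nnc(-c3ccccc3Cl)o2)c(C)c1` differs from compound 3 by chloro in place of hydrogen on an aromatic carbon; this is the same kind of change as from compound 1 to compound 2, but the place differs: para to a large group there, ortho to a large group here. Compound 4 is therefore expected to move by a number 14 percentage points higher from compound 3 to compound 4 (beyond the scatter), in the same direction as compound 2 but less certain in size, because the earlier step of a number 23.3 percentage points higher from compound 1 to compound 2 (beyond the scatter) was measured at a different place. The estimate for compound 4 is 50%, between 30% and 70%.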

Compound 4, a percentage reported as inhibition, in the whole organism at one dose (the size of the read-out at that dose, not a potency): 33.5%
For compound 4 the middle estimate is 16.5 percentage points above the measured one; measured number inside the range.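

In this assay, chloro in place of hydrogen gave a number 2.5 percentage points lower from compound 3 to compound 4 (within the scatter), so the change did not bring on this core what it brought on the core of compound 1. The two steps do not agree: the same change on two cores in this assay, a number 23.3 percentage points higher (beyond the scatter) from compound 1 to compound 2 and a number 2.5 percentage points lower (within the scatter) from compound 3 to compound 4, 25.8 percentage points apart, beyond the scatter of two such steps. This shows that the size of the step cannot simply be carried from one core to the other in this series, but it does not show whether core or place is responsible, since the new chloro sits ortho to a large group and the two pairs differ in both respects.

The compounds shown leave open what chloro would do at one same place on both cores. They also leave open how a different group on that phenyl ring, such as methoxy or an amine, would behave.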